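Chloro removal on the aromatic ring: compound 1 to compound 3

The source may hold more compounds than are shown below. What is called first, only, known or untested is meant among the compounds shown, and "the series" means these compounds.

Of the compounds shown here, two have numbers so far. Compound 1 `COc1cc(/C=C/C(=O)c2cccc(-n3cc(-c4ccc(Cl)cc4)[nH]c3=O)c2)ccc1O` carries a 4-chlorophenyl group on the shared core; in a functional assay on SNB-19 cells (Homo sapiens) for inhibition (on this read-out higher numbers stand for weaker inhibition of growth and lower numbers for stronger inhibition of growth), compound 1 gives 3170 nM. Compound 2 `COc1cc(/C=C/C(=O)c2cccc(-n3cc(-c4ccccc4)[nH]c3=O)c2)cc(OC)c1OC` differs from compound 1 in more than one place; in this assay compound 2 gives 2350 nM. Compound 1 stands at one end of the two numbers shown, and its nearest neighbour, compound 2, lies within the scatter of it, so the two cannot be told apart on this read-out. Since compound 2 is not a single-point change, no step can be read from that pair.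

Compound 3 `COc1cc(/C=C/C(=O)c2cccc(-n3cc(-c4ccccc4)[nH]c3=O)c2)ccc1O` is not yet measured in this assay. It differs from compound 1 as follows: hydrogen in place of chloro on an aromatic carbon. For the measured compounds named here, no measured pair shows what this change alone does here. The step from compound 1 to compound 3 is expected to be small, a 1.3-fold higher number from compound 1 to compound 3 (0.10 log units; within the scatter), and not beyond the scatter. The estimate for compound 3 is 4000 nM, within a range from 1500 nM to 10000 nM.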

Compound 3, concentration for 50% growth inhibition: 2960 nM
Compound 3: middle estimate off by 1.4-fold (0.13 log units), on the high side, within the range that was stated.
By their numbers in this assay, from the lowest: compounds 2, 3 and 1 (each within the scatter of the next).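

In this assay, for the compounds shown here, the first single-point step reads a 1.1-fold lower number from compound 1 to compound 3 (0.03 log units; within the scatter), so the 4-chlorophenyl and phenyl forms cannot be told apart on this read-out. At this place on the aromatic ring, para to a large group, hydrogen in place of chloro therefore leaves no mark that this read-out can resolve, although this rests on a single pair. Going by these compounds alone, no independent measurement bears on this result, so it offers no account of the step.

The compounds shown carry only chloro or hydrogen at this place, so they leave open whether the number would respond to an amine, a carboxylic acid or a longer chain such as butyl there. As far as these compounds go, whether the same swap behaves alike on a different substitution pattern at the other end of the molecule also remains open.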